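The source may report more compounds than this note shows. Statements on the series, on what has been measured and on what is new or still open speak of the compounds shown alone.

Compound 1 `ClCc1ccc(Cn2cnc3c(Cl)ncnc32)cc1` was tested in a functional assay on NCI-H522 cells (Homo sapiens) for cytotoxicity, read by sulforhodamine B assay, with a stated time of 48 h; on this read-out lower numbers stand for stronger inhibition of growth and higher numbers for weaker inhibition of growth. In this assay compound 1 gives only a limit, > 100000 nM, which is not a number but the boundary of what the test can report. Compound 1 therefore stands at the limit of > 100000 nM in this assay, at which 1 of the 2 values shown sits, the weaker end of what was seen. Compound 2 `ClCc1ccccc1Cn1cnc2c(Cl)ncnc21` was tested as well, and in this assay compound 2 gives 7240 nM. For the measured compounds named here, no single-change step between measured compounds is available here. Compound 3 `ClCc1ccc(Cn2cnc3c(Cl)nc(Cl)nc32)cc1` has not been measured. It differs from compound 1 by chloro in place of hydrogen on an aromatic carbon. Since compound 1 reaches only a limit, the step from compound 1 to compound 3 cannot be tied to any measured change, and the expectation is for little movement beyond the usual scatter, as expressed in an at least 1.4-fold lower number from compound 1 to compound 3 (0.15 log units; that floor lies within the scatter). Compound 3 is estimated at 70000 nM, with a range from 15000 nM to 200000 nM, and a fair chance that only a limit is reported again.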

Compound 3, concentration for total growth inhibition: 46800 nM
Compound 3: middle estimate off by 1.5-fold (0.17 log units), on the high side; low and high end bracket the measured number.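

In this assay, chloro in place of hydrogen on the aromatic carbon between two ring nitrogen atoms brings an at least 2.1-fold lower number from compound 1 to compound 3 (0.32 log units; beyond the scatter). For the compounds shown here, this is the first sign that this position matters for growth inhibition in these cells, as compound 3 gives a measured number where compound 1 gives only a limit. The true size of the step remains unknown, and the printed figure is only a floor, because one end of the step is a limit: the limit of > 100000 nM in this assay, at which 1 of the 3 values shown sits.

As far as these compounds go, whether an amine, a methyl group or a fluoro group at this position would lower the number as well stays open. Also open, from the compounds shown here alone, is whether the same chloro group would shift the number of compound 2, which gives 7240 nM in this assay.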